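This account rests on a few compounds, and the source may have more. Where it says the series, first, only, none or still open, it means among the compounds named here.

Values so far in a functional assay on the whole organism with Mus musculus as the target (a higher number here means that more compound is needed for the effect, a lower number that less compound is needed), are as follows:
- Compound 1 `CN(C)C(=O)Cn1c(-c2ccccc2)nc2cccnc21` gives 35 mg/kg
- Compound 2 `Cc1ccc(-c2nc3cccnc3n2CC(=O)N(C)C)cc1` gives 4.7 mg/kg

Compound 2 holds the lower of the two numbers, so less of it is needed for the effect than of compound 1. The next compound to be measured is compound 3 `CN(C)C(=O)Cn1c(-c2ccsc2)nc2cccnc21`, which differs from compound 2 on the shared core as follows: thiophen-3-yl in place of 4-methylphenyl on an aromatic carbon, with thiophen-3-yl in place of 4-methylphenyl on an aromatic carbon.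

Within the data shown here, only one measured step bears on this change. It is a 7.4-fold lower number from compound 1 to compound 2 (0.87 log units; beyond the scatter), and it came with methyl in place of hydrogen on an aromatic carbon. The thiophen-3-yl of compound 3 carries no such methyl, so the number is expected to rise back toward compound 1 at 35 mg/kg in this series. Among the measured compounds shown here, no compound measured so far carries a five-membered ring at this place, so this single step is only a weak guide and the range must stay wide. For compound 3 the estimated value is 22 mg/kg within an expected range of 6 mg/kg to 80 mg/kg in this assay for now. The expected change is a 4.7-fold higher number from compound 2 to compound 3 (0.67 log units; beyond the scatter) and would mean that more compound is needed.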

Compound 3, dose for half-maximal effect: 38 mg/kg
Compound 3: the middle estimate sits 1.7-fold (0.24 log units) below what was measured; the range from low to high includes it.
By their numbers in this assay, from the lowest: compound 2; then compounds 1 and 3 (each within the scatter of the next).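

In this assay, the aromatic carbon between two ring nitrogen atoms now has a change of ring to read alongside the earlier methyl step: replacing 4-methylphenyl with thiophen-3-yl gives an 8.1-fold higher number from compound 2 to compound 3 (0.91 log units; beyond the scatter) and so loses the advantage held by compound 2. Set against the plain phenyl, thiophen-3-yl gives a 1.1-fold higher number from compound 1 to compound 3 (0.04 log units; within the scatter) and so leaves the dose needed unchanged within the scatter, which shows that this five-membered ring with its sulfur can stand in for phenyl here without a measurable difference, while only 4-methylphenyl stands apart among the three groups. Nothing measured here explains why the methyl matters at this place or why the two rings without it read alike.

The compounds shown leave open whether a methyl on the thiophen-3-yl would bring the same drop as it does on phenyl, and whether a chlorine or a methoxy group on the phenyl would do what the methyl does. The (dimethylcarbamoyl)methyl group is also the same in all three compounds, so a different amide or a longer chain there remains an open question.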